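A few compounds are considered here, and "the series" means these few. Any claim that something is new, unique, unknown or untested is made for them only; others in the source may bear on it.

In a functional assay on A549 cells (Homo sapiens) for cytotoxicity, read by MTT assay, with a stated time of 72 h (a higher number here means a weaker inhibitor, a lower number a stronger inhibitor), compound 1 `CNC(=O)c1cc(Oc2ccc(NC(=O)c3nccc(-c4ccccc4)n3)cc2)ccn1` gives 26200 nM and compound 2 `CCc1ccc(-c2cc(C(=O)Nc3ccc(Oc4ccnc(C(=O)NC)c4)cc3)ncn2)cc1` gives 13300 nM so these two stand within the scatter of each other, and compound 1 has no clear place above or below its nearest neighbour. Compound 3 `CNC(=O)c1cc(Oc2ccc(NC(=O)c3cc(-c4ccc(C(F)(F)F)cc4)ncn3)cc2F)ccn1` gives > 100000 nM as a limit of the assay and not a number. The difference nitro in place of hydrogen on an aromatic carbon leads to compound 4 `CNC(=O)c1cc(Oc2ccc(NC(=O)c3nccc(-c4ccc([N+](=O)[O-])cc4)n3)cc2)ccn1` which carries nitro in place of hydrogen on an aromatic carbon, para to a large group, so that phenyl becomes 4-nitrophenyl. Among the compounds with values here, no measured pair isolates this change, which leaves this assay without a direct guide. What is expected is a 1.5-fold lower number from compound 1 to compound 4 (0.16 log units; within the scatter) with no shift beyond the scatter in either direction. For compound 4 the estimated value is 18000 nM with an expected range from 5000 nM to 60000 nM in this estimate.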

Compound 4, half-maximal inhibitory concentration: > 100000 nM
Compound 4 was reported as a limit; the forecaster's own chance of this, stated with the estimate: 12%; middle value at least 5.5-fold (0.74 log units) away from the limit.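

In this assay, nitro in place of hydrogen on an aromatic carbon, para to a large group, gives an at least 3.8-fold higher number from compound 1 to compound 4 (0.58 log units; beyond the scatter). Within the data shown here, this is the first single-place change that can be read, and it shows that this position on the phenyl ring is not indifferent to substitution. Compound 4 carries a limit and not a number, so the step gives only a lower bound on the change: the limit of > 100000 nM in this assay, at which 2 of the 4 values shown sit.

The compounds shown leave open how an amine or a carboxylic acid at the same position would compare with hydrogen and nitro. They also leave open whether a smaller group, such as fluorine or methyl, would move the number at all.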